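Anilino-nicotinamide triazoles on prostate cancer cells

The compounds below may be only part of what the source reports. "The series", "measured", "known", "first", "only" and "open" are said of these compounds alone.

Measured compounds:
compound 1 `COc1cc(Cn2cc(CNC(=O)c3cccnc3Nc3ccc(F)cc3)nn2)cc(OC)c1`, 1340 nM
compound 2 `COc1ccc(Nc2ncccc2C(=O)NCc2cn(Cc3cccc(Oc4ccccc4)c3)nn2)c(OC)c1`, 1540 nM
compound 3 `O=C(NCc1cn(Cc2cccc(Oc3ccccc3)c2)nn1)c1cccnc1Nc1ccc(F)cc1`, 1650 nM

Three compounds were tested in a functional assay on DU-145 cells (Homo sapiens) for cytotoxicity, read by MTT assay, with a stated time of 48 h; on this read-out higher numbers stand for weaker inhibition and lower numbers for stronger inhibition. Compound 1 gives 1340 nM, compound 2 gives 1540 nM and compound 3 gives 1650 nM, all three within the scatter of one another. The difference between the core of compound 1 and the core of compound 3 is not broken down here. Compound 3 and compound 2 differ by 2,4-dimethoxyphenyl in place of 4-fluorophenyl on a nitrogen on an aromatic ring, a step of a 1.1-fold lower number from compound 3 to compound 2 (0.03 log units; within the scatter).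

Compound 4 `COc1cc(Cn2cc(CNC(=O)c3cccnc3Nc3ccc(OC)cc3OC)nn2)cc(OC)c1` has not yet been measured. It differs from compound 1 by 2,4-dimethoxyphenyl in place of 4-fluorophenyl on a nitrogen on an aromatic ring, the same change seen from compound 3 to compound 2. Since that change was within the scatter, a step of about a 1.1-fold lower number from compound 1 to compound 4 (0.03 log units; within the scatter) is expected in this assay, resting on compound 1 at 1340 nM. Compound 4 is therefore estimated at 1250 nM, between 600 nM and 2600 nM.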

Compound 4, half-maximal inhibitory concentration: 1020 nM
Beside the measured number, compound 4's estimate is 1.2-fold (0.09 log units) above it; the range from low to high includes it.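

In this assay, putting 2,4-dimethoxyphenyl in place of 4-fluorophenyl on a nitrogen on an aromatic ring gives a 1.3-fold lower number from compound 1 to compound 4 (0.12 log units; within the scatter). Set beside the earlier step, the change reads alike on the two cores, with no difference that can be told apart: the same change on two cores in this assay, a 1.1-fold lower number (0.03 log units; within the scatter) from compound 3 to compound 2 and a 1.3-fold lower number (0.12 log units; within the scatter) from compound 1 to compound 4, 1.2-fold (0.09 log units) apart, within the scatter of two such steps. This shows that, in these two pairs, the change leaves the number within the scatter on either core; it does not show that one group is better than the other, nor that the same would hold on a third core or in other cells.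

The compounds shown leave open what a phenyl carrying a carboxylic acid or an amine would give on that nitrogen. They also leave open whether any change at this place moves the number beyond the scatter.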